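Furan to thiophene on the ketone of compound 2

The source may report more compounds than this note shows. Statements on the series, on what has been measured and on what is new or still open speak of the compounds shown alone.

Compounds measured so far:
compound 1 `COc1cc(O)ccc1/C=C/C(=O)c1ccc(N)cc1` — "not determined" (no result reported)
compound 2 `COc1ccc(/C=C/C(=O)c2ccco2)cc1Br` — 10900 nM
compound 3 `COc1ccc(C(=O)/C=C/c2ccc(OC)c(Br)c2)c(O)c1` — "not determined" (no result reported)

In a functional assay on T47D cells (Homo sapiens) for cytotoxicity, read by MTT assay (a lower number here means a stronger inhibitor, a higher number a weaker inhibitor), only compound 2 `COc1ccc(/C=C/C(=O)c2ccco2)cc1Br` carries a number, 10900 nM. For compound 1 the entry reads "not determined" (no result reported), and for compound 3 it reads "not determined" (no result reported), so no result is reported for either, and nothing can be said of how compound 2 stands against them. Compound 2 therefore stands alone as the single measured point in this assay, a weak inhibitor by its own value.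

Compound 4 `COc1ccc(/C=C/C(=O)c2cccs2)cc1Br` differs from compound 2 in one place: thiophen-2-yl in place of furan-2-yl on a carbonyl carbon. Within the data shown here, no pair of measured compounds shows what this change does, so the step has to be guessed from the single value. An exchange of one five-membered aromatic ring with one hetero atom for another is expected to move the number by little, probably within the usual scatter, with at most a slight shift toward a stronger inhibitor.

The expected step from compound 2 to compound 4 is a 1.4-fold lower number from compound 2 to compound 4 (0.13 log units; within the scatter). For compound 4 the estimate in this assay is 8000 nM, with a range from 3000 nM to 25000 nM.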

Compound 4, half-maximal inhibitory concentration: 21900 nM
Compound 4: the middle estimate sits 2.7-fold (0.44 log units) below what was measured; measured number inside the range.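

Among these compounds, the exchange of furan-2-yl for thiophen-2-yl on the carbonyl carbon gives the first readable step at this position: a 2.0-fold higher number from compound 2 to compound 4 (0.30 log units; within the scatter) in this assay. On this evidence the two five-membered aromatic rings, each with one hetero atom, cannot be told apart in this assay, so replacing oxygen with sulfur in the ring at this position leaves the result within the noise of the measurement. Nothing available explains this outcome or connects it to any property of either ring.

Steps involving compound 1 and compound 3 cannot be read, so the other groups they carry on the carbonyl cannot be compared with these two rings. On these data alone, it also remains open whether a pyridin-2-yl or pyrrol-2-yl group on the same carbonyl carbon would move the number beyond the scatter.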